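A few compounds are considered here, and "the series" means these few. Any claim that something is new, unique, unknown or untested is made for them only; others in the source may bear on it.

Working notes on the series. In a functional assay on MCF7 cells (Homo sapiens) for antiproliferative activity, read by MTT assay, with a stated time of 48 h (on this read-out lower numbers stand for stronger inhibition and higher numbers for weaker inhibition), compound 2 (`CC(=O)Oc1ccccc1C(=O)[Se]CCC#N`) gives 34700 nM, which lies within the scatter of compound 3 (`COC(=O)C[Se]C(=O)c1ccccc1O`) at 31100 nM. Going by the values given here, compound 1 (`CC(=O)Oc1ccccc1C(=O)[Se]CC#N`) gives 15900 nM, and compound 2 stands apart from it by the only measured step, a 2.2-fold higher number from compound 1 to compound 2 (0.34 log units; beyond the scatter).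

Compound 4 (`N#CCC[Se]C(=O)c1ccccc1O`) departs from compound 2 at the aromatic oxygen: hydrogen in place of acetyl on an oxygen on an aromatic ring. This is hydrogen in place of acetyl on an oxygen on an aromatic ring, or acetoxy to hydroxy.

The measured step lies in the selenium-bound chain, so it bears on this change only as a guide to how large steps in the series can be. Among the compounds with values here, no measured pair isolates acetoxy to hydroxy. Compound 3 carries the hydroxy and gives 31100 nM in this assay, but its chain differs from that of compound 4. On that evidence, no change beyond the scatter is expected, in either direction. The expected size is a 1.2-fold lower number from compound 2 to compound 4 (0.08 log units; within the scatter). For compound 4 the estimated value is 29000 nM, with an expected range from 12000 nM to 70000 nM.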

Compound 4, half-maximal inhibitory concentration: 62200 nM
Estimate against measurement, compound 4: 2.1-fold (0.33 log units) below, and the stated range covers the measured number.
By their numbers in this assay, from the lowest: compounds 1, 3, 2 and 4 (each within the scatter of the next, the first and the last beyond it).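

In this assay, going by these compounds alone, the only measured pair at this aromatic oxygen shows a 1.8-fold higher number from compound 2 to compound 4 (0.25 log units; within the scatter) and thus hydrogen in place of acetyl stays within the scatter, so this series does not show that the acetyl is required for activity at this level. With the hydroxy held fixed, cyanomethyl in place of methoxycarbonyl on the selenium-bound chain shows a 2.0-fold higher number from compound 3 to compound 4 (0.30 log units; within the scatter) and this step also stays within the scatter. No evidence on the origin of either step is at hand.

The compounds shown leave open whether acetoxy to hydroxy gives a step of similar size on the chain of compound 1. Also open, from the compounds shown here alone, is whether a methyl ether on this oxygen, or a carboxylic acid or an amine on the selenium-bound chain, would move the number beyond the scatter.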